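The compounds below may be only part of what the source reports. "The series", "measured", "known", "first", "only" and "open" are said of these compounds alone.

Measured so far in a functional assay on the whole organism with Mus musculus as the target; a higher number here means that more compound is needed for the effect, a lower number that less compound is needed:

- compound 1 `Cc1c(N)c(C)c2c(c1CN1CCCCC1)OC(C)(C)C2`: > 50 mg/kg
- compound 2 `Cc1c(C)c2c(c(C)c1N)CC(C)(CSc1ccccc1)O2`: 24.7 mg/kg

Compound 1 has only a limit of the assay, > 50 mg/kg, and not a number. Going by the values given here, compound 2, at 24.7 mg/kg, is the only compound with an actual number, so there is no other measured value to rank it against.

The next compound is compound 3 `Cc1c(C)c2c(c(C)c1N)CC(C)(CSc1nccn1C)O2`. It keeps the shared core and the saturated chain carbon on the sulfur, and has 1-methyl-1H-imidazol-2-yl in place of phenyl on a sulfur. Among the compounds with values here, no pair of measured compounds differs in one place only, so the data give no size for a change of this kind.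

In this assay, the estimate therefore stays anchored to compound 2 at 24.7 mg/kg, with a wide margin on both sides. The expected step of a 1.2-fold higher number from compound 2 to compound 3 (0.08 log units; within the scatter) lies within the usual scatter, with neither direction favoured. For compound 3 the estimated value is 30 mg/kg, with an expected range of 12 mg/kg to 70 mg/kg.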

Compound 3, dose for 50% inhibition: 37.1 mg/kg
For compound 3 the middle estimate is 1.2-fold (0.09 log units) below the measured one, and the stated range covers the measured number.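

In this assay, going by these compounds alone, replacing phenyl with 1-methyl-1H-imidazol-2-yl on a sulfur whose other neighbour is a saturated chain carbon gives the first readable step: a 1.5-fold higher number from compound 2 to compound 3 (0.18 log units; within the scatter). This position therefore accepts a five-membered aromatic ring with 2 hetero atoms and 2 hydrogen-bond acceptors in place of a six-membered aromatic ring of carbon only, with no shift beyond the scatter, so compound 2 and compound 3 cannot be placed in any order. The one limit in the set plays no part in this reading, as the step rests on two actual numbers and the limit belongs to a compound that differs in more than one place: the limit of > 50 mg/kg in this assay, at which 1 of the 3 values shown sits.

As far as these compounds go, a single step says nothing about how wide this tolerance is, so it remains open whether a non-aromatic group on the sulfur, such as a cyclohexyl ring, a short alkyl chain or a chain ending in a carboxylic acid, would move the dose beyond the scatter. From the compounds shown here alone, the role of the sulfur itself also remains open, as would be tested by an oxygen or a sulfone at that place.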